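The source may hold more compounds than are shown below. What is called first, only, known or untested is meant among the compounds shown, and "the series" means these compounds.

Cytotoxicity series on a shared core, read in a functional assay on Ehrlich cells (Mus musculus) for cytotoxicity, tested at 10 ug/mL; on this read-out higher numbers stand for a stronger effect at the one concentration tested and lower numbers for a weaker effect:

- compound 1 `COc1ccc(C2C(C#N)=C(N)N(c3cc(OC)c(OC)c(OC)c3)C3=C2C(=O)CC(C)(C)C3)cc1`: 0%
- compound 2 `COc1cc(N2C(N)=C(C#N)C(c3ccc(OC)c4ccccc34)C3=C2CC(C)(C)CC3=O)cc(OC)c1OC`: 10%
- compound 3 `COc1cc(N2C(N)=C(C#N)C(c3cccc([N+](=O)[O-])c3)C3=C2CC(C)(C)CC3=O)cc(OC)c1OC`: 5%

Compound 1 gives the smallest of the three numbers, yet neither gap separates it from the others: the move a number 5 percentage points higher from compound 1 to compound 3 (within the scatter) and the move a number 10 percentage points higher from compound 1 to compound 2 (within the scatter) both stay inside the usual scatter, as does the move a number 5 percentage points lower from compound 2 to compound 3 (within the scatter). Across the three aryl groups on the saturated ring carbon the read-out is essentially flat and low.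

Compound 4 `COc1cc(N2C(N)=C(C#N)C(c3cccs3)C3=C2CC(C)(C)CC3=O)cc(OC)c1OC` is the next variation at the same position. The change from compound 1 is thiophen-2-yl in place of 4-methoxyphenyl on a saturated ring carbon. Within the data shown here, the steps that bear on it are the two swaps already made at this carbon; both were small and did not leave the scatter, so the expectation for compound 4 is a step of similar size, i.e. none that can be told from noise in this assay. The estimated step is a number 5 percentage points higher from compound 1 to compound 4 (within the scatter), which is within the scatter. Compound 4 is accordingly expected to read 5%, with a range from 0% to 20% in this assay.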

Compound 4, a percentage reported as activity, at one concentration (the size of the read-out at that concentration, not a potency): 5%
Compound 4: middle estimate and measured number agree at the digits printed; low and high end bracket the measured number.
By their numbers in this assay, from the lowest: compounds 1, 3, 4 and 2 (each within the scatter of the next).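

In this assay, thiophen-2-yl on the saturated ring carbon brings a five-membered aromatic ring with 1 hetero atom to a position that so far held only aromatic rings of carbon, and the read-out cannot be told apart from that of any earlier group: a number 5 percentage points higher from compound 1 to compound 4 (within the scatter), no change at the digits printed from compound 3 to compound 4 (within the scatter) and a number 5 percentage points lower from compound 2 to compound 4 (within the scatter). The flat, low picture at this position therefore covers a sulfur-bearing aromatic ring as well as 4-methoxyphenyl, 3-nitrophenyl and 4-methoxynaphthalen-1-yl, and none of the compounds 1 to 4 goes against it, though the pattern holds only for these four aromatic groups. No supporting measurement accompanies these numbers that could account for this flat result.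

Still open, on these data alone, is whether anything at this carbon moves the read-out beyond the scatter, for example a saturated cyclohexyl group, a basic aminoalkyl chain or a carboxylic acid on the aromatic ring. Also open, as far as these compounds go, is whether the low numbers depend on the 3,4,5-trimethoxyphenyl group, which is common to all four compounds and could be tested by replacing it with a plain phenyl or a benzyl group.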